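From dimethoxyphenyl to difluorophenyl, with only limits to go on

A few compounds are considered here, and "the series" means these few. Any claim that something is new, unique, unknown or untested is made for them only; others in the source may bear on it.

Results so far in a functional assay on B16 cells (Mus musculus) for antiproliferative activity, with a stated time of 72 h; a lower number here means a stronger inhibitor, a higher number a weaker inhibitor:
Compound 1 `OC[C@H]1O[C@@H](n2cnc3c(NCc4ccccc4Br)ncnc32)[C@H](O)[C@@H]1O` reads > 166000 nM (a limit of the assay)
Compound 2 `COc1cccc(CNc2ncnc3c2ncn3[C@@H]2O[C@H](CO)[C@@H](O)[C@H]2O)c1` reads > 166000 nM (a limit of the assay)
Compound 3 `COc1cccc(CNc2ncnc3c2ncn3[C@@H]2O[C@H](CO)[C@@H](O)[C@H]2O)c1OC` reads "not determined" (no result reported) (no result)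

Compound 3 has no number of its own in this assay, and its two relatives offer only the limit of > 166000 nM in this assay, at which 2 of the 3 values shown sit (a limit, not a measured number). Compound 4 `OC[C@H]1O[C@@H](n2cnc3c(NCc4ccc(F)cc4F)ncnc32)[C@H](O)[C@@H]1O` puts 2,4-difluorophenyl in place of the 2,3-dimethoxyphenyl of compound 3, on a saturated chain carbon bound to a nitrogen on an aromatic ring (2,4-difluorophenyl in place of 2,3-dimethoxyphenyl on a saturated chain carbon bound to a nitrogen on an aromatic ring). Within the data shown here, the only measured step that bears on this swap is a step that the two limits leave unreadable from compound 1 to compound 2, so it supplies no size to carry over. Among the measured compounds shown here, no step of any particular size or direction can therefore be expected in this assay. Compound 2 stays at the limit > 166000 nM in this comparison, and the same outcome is the likeliest expectation for compound 4. The estimated value for compound 4 is 166000 nM, with an expected range from 40000 nM to 300000 nM.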

Compound 4, half-maximal inhibitory concentration: > 166000 nM
Compound 4: no number, only a limit; the forecaster's own chance of this, stated with the estimate: 75%; the middle value sits exactly at the limit.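

Compound 1, compound 2 and compound 4 give only limits in this assay, not numbers, so no step among them can be read: the limit of > 166000 nM in this assay, at which 3 of the 4 values shown sit.

The compounds shown leave open where compound 3 stands and whether any group in this place gives a readable value in this assay.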